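A few compounds are considered here, and "the series" means these few. Any claim that something is new, unique, unknown or untested is made for them only; others in the source may bear on it.

Measured compounds in this study:

Compound 1, `COc1cccc2cc(C(=O)O)cnc12`: 150 mg/kg
Compound 2, `O=C(O)c1cnc2cc(C(F)(F)F)ccc2c1`: > 25 mg/kg (a limit of the assay)
Compound 3, `COc1cccc2c(=O)c(-c3nn[nH]n3)c[nH]c12`: 0.312 mg/kg

All three were tested in a functional assay on the whole organism (strain Sprague-Dawley) for inhibition, with Rattus norvegicus as the target; a higher number here means that more compound is needed for the effect, a lower number that less compound is needed. Compound 1 gives 150 mg/kg. Compound 2 sits at the limit of > 25 mg/kg in this assay, at which 1 of the 3 values shown sits; this is a limit of the assay and not a number. Compound 3 gives 0.312 mg/kg, the lowest of the two numbers shown; compound 1 holds the other, higher one, and the gap between the two is well beyond the usual scatter. No pair of these compounds differs in only one place, so no single measured step can be read from them.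

Compound 4, `CC(C)c1cccc2c(=O)c(-c3nn[nH]n3)c[nH]c12`, has not yet been measured in this assay. It differs from compound 3 in one place: isopropyl in place of methoxy on an aromatic carbon. Since no measured step of a comparable kind is available among these compounds, the expectation rests on compound 3 alone. The step is expected to be a 1.6-fold higher number from compound 3 to compound 4 (0.20 log units; within the scatter), that is, little change or a slight rise in the number, likely within the scatter of the assay. Compound 4 is accordingly estimated at 0.5 mg/kg, with a range from 0.1 mg/kg to 3 mg/kg.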

Compound 4, minimum effective dose: 10 mg/kg
Estimate against measurement, compound 4: 20-fold (1.30 log units) below; measured number above the stated range.
By their numbers in this assay, from the lowest: compound 3; then compound 4; then compound 1.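

Within this assay the swap of methoxy for isopropyl on this aromatic carbon gives a 32-fold higher number from compound 3 to compound 4 (1.51 log units; beyond the scatter) and this is the first change in the study that can be read in a single place. With the rest of the molecule the same, the result shows that this position is not indifferent to the group it carries: a modest change of substituent, one heavy-atom count apart under the computed comparison, moves the dose needed well beyond the usual scatter, and in the direction of needing more compound. Nothing among the data shown accounts for the size of this step.

For the compounds shown here, only two groups are compared at this carbon, so it stays open whether the oxygen of methoxy or the branched carbon chain of isopropyl matters more, and a hydroxyl, an ethoxy or an ethyl group at the same place would help to separate the two. Going by these compounds alone, compounds 1 and 2 differ from these two compounds in more than one place, so no step to them can be read, and whether this preference holds on another core remains unknown.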